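Amide variation on the shared core: compound 4

The source may hold more compounds than are shown below. What is called first, only, known or untested is meant among the compounds shown, and "the series" means these compounds.

Measured so far:
compound 1 `O=C(Nc1nc(-c2ccccc2)nc2c1nnn2Cc1ccccc1)c1cccc([N+](=O)[O-])c1` — in an assay (strain Wistar) for displacement of a labelled ligand from adenosine receptor A1 (Rattus norvegicus), read by scintillation counting (a higher number here means a weaker inhibitor, a lower number a stronger inhibitor), compound 1 gives 77 nM
compound 2 `O=C(Nc1nc(-c2ccccc2)nc2c1nnn2Cc1ccccc1)C1CC1` — in this assay compound 2 gives 7.5 nM
compound 3 `COc1ccc(Cl)cc1C(=O)Nc1nc(-c2ccccc2)nc2c1nnn2Cc1ccccc1` — in this assay compound 3 gives 7150 nM

Compound 3 stands highest of the three numbers, and both gaps are beyond the scatter: a 93-fold higher number from compound 1 to compound 3 (1.97 log units; beyond the scatter) and a 950-fold higher number from compound 2 to compound 3 (2.98 log units; beyond the scatter). Compound 4 `Cc1ccc(C(=O)Nc2nc(-c3ccccc3)nc3c2nnn3Cc2ccccc2)cc1` differs from compound 3 in one place: 4-methylphenyl in place of 5-chloro-2-methoxyphenyl on a carbonyl carbon. Among the compounds with values here, no measured step reproduces this exact exchange. Within the data shown here, two steps bear on it, since both bring the 5-chloro-2-methoxyphenyl group onto the carbonyl carbon and both are large rises in the number: a 93-fold higher number from compound 1 to compound 3 (1.97 log units; beyond the scatter) from a 3-nitrophenyl start, a 950-fold higher number from compound 2 to compound 3 (2.98 log units; beyond the scatter) from a cyclopropyl start. The third step, a 10-fold lower number from compound 1 to compound 2 (1.01 log units; beyond the scatter), shows the spread between the two other amides. Removing the 5-chloro-2-methoxyphenyl group is therefore expected to undo most of the rise seen in compound 3, so a large fall in this assay is expected, roughly of the size of the step from compound 1 to compound 3 in the opposite direction. The expected step in this assay is estimated as a 60-fold lower number from compound 3 to compound 4 (1.78 log units; beyond the scatter). Among the measured compounds shown here, on this basis compound 4 is estimated at 120 nM in this assay, with a range from 25 nM to 700 nM; the range is wide since no measured pair contains a 4-methylphenyl amide.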

Compound 4, inhibition constant: 709 nM
Compound 4: the middle estimate sits 5.9-fold (0.77 log units) below what was measured; measured number outside the range, above it.
By their numbers in this assay, from the lowest: compound 2; then compound 1; then compound 4; then compound 3.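

The exchange in this assay gives a 10-fold lower number from compound 3 to compound 4 (1.00 log units; beyond the scatter) ( a step of about the same size as a 10-fold lower number from compound 1 to compound 2 (1.01 log units; beyond the scatter)), so the very high number of compound 3 is not common to every substituted phenyl on this carbonyl carbon. Compound 4 still stands apart from both other amides, with a 9.2-fold higher number from compound 1 to compound 4 (0.96 log units; beyond the scatter) and a 95-fold higher number from compound 2 to compound 4 (1.98 log units; beyond the scatter), so the 4-methylphenyl amide does not recover the level of either. With a fourth compound in hand, the three phenyl amides (compound 1, compound 4, compound 3) spread over a wide range, and all three stand above the cyclopropyl amide compound 2, which remains the strongest of the four in this assay.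

Compound 3 and compound 4 differ in the chloro, methoxy and methyl groups at once, so a 2-methoxyphenyl or a 3-chlorophenyl amide would be needed to separate their shares of the step, while an unsubstituted phenyl amide and an open-chain isopropyl amide would test how far the low number of compound 2 extends beyond cyclopropyl. Nothing measured here accounts for any of these differences.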